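The source may report more compounds than this note shows. Statements on the series, on what has been measured and on what is new or still open speak of the compounds shown alone.

Compound 1 `CC1(C)[C@H]2CC[C@]1(C)N(Cc1cn(-c3ccc(C#N)cc3)nn1)C(=O)C2` is the anchor of this comparison. In a functional assay on HepG2 cells (Homo sapiens) for inhibition, read by MTT assay, with a stated time of 24 h (on this read-out lower numbers stand for stronger inhibition and higher numbers for weaker inhibition), compound 1 gives 50 nM, the lowest of the three numbers measured. Compound 2 `CC1(C)[C@H]2CC[C@]1(C)N(Cc1cn(-c3ccccc3C#N)nn1)C(=O)C2` gives 180 nM, and compound 3 `COc1ccccc1-n1cc(CN2C(=O)C[C@@H]3CC[C@@]2(C)C3(C)C)nn1` gives 110 nM. The two steps away from compound 1 are a 3.6-fold higher number from compound 1 to compound 2 (0.56 log units; beyond the scatter) and a 2.2-fold higher number from compound 1 to compound 3 (0.34 log units; beyond the scatter); the step between the other two, a 1.6-fold lower number from compound 2 to compound 3 (0.21 log units; within the scatter), stays within the scatter.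

Compound 4 `CC1(C)[C@H]2CC[C@]1(C)N(Cc1cn(-c3ccc(Br)cc3)nn1)C(=O)C2` differs from compound 1 in one place: bromo in place of cyano on an aromatic carbon. Among the compounds with values here, none of the measured steps makes this same exchange. The closest lesson is a 1.6-fold lower number from compound 2 to compound 3 (0.21 log units; within the scatter), where swapping one group for another on the same aromatic carbon shifted the number only within the scatter, while the larger shifts came from changing the whole aryl group. A small step is therefore expected in this assay, more likely upward than downward, a 1.7-fold higher number from compound 1 to compound 4 (0.23 log units; within the scatter). Compound 4 is estimated at 85 nM, with a range from 30 nM to 250 nM.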

Compound 4, half-maximal inhibitory concentration: 110 nM
Beside the measured number, compound 4's estimate is 1.3-fold (0.11 log units) below it; low and high end bracket the measured number.
By their numbers in this assay, from the lowest: compound 1; then compounds 3, 4 and 2 (each within the scatter of the next).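

In this assay, bromo on the aromatic carbon that holds the nitrile in compound 1 gives a 2.2-fold higher number from compound 1 to compound 4 (0.34 log units; beyond the scatter), so exchanging this one group, with the rest of the aryl group unchanged, is enough to move the number beyond the scatter. The other steps to compound 4 are no change at the digits printed from compound 3 to compound 4 (within the scatter) and a 1.6-fold lower number from compound 2 to compound 4 (0.21 log units; within the scatter), which leaves compound 4 level with both 2-substituted aryl compounds, while compound 1 keeps the lowest number of the four. No measured evidence bears on what lies behind these steps.

Going by these compounds, an amine or a carboxylic acid on this same carbon could read either way, so it remains unknown how far the number depends on the nitrile itself. On these data alone, whether 2-bromophenyl would read differently from 4-bromophenyl also stays open.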